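Selenium for Sulfur on a Furan-Bearing Core

A few compounds are considered here, and "the series" means these few. Any claim that something is new, unique, unknown or untested is made for them only; others in the source may bear on it.

The study compares four acylated isothiourea-type compounds in an ADME assay on MCF-10A cells (Homo sapiens) for cytotoxicity, read by MTT assay, with a stated time of 72 h; a higher number here means a weaker inhibitor of growth, a lower number a stronger inhibitor of growth. Compound 3 `CS/C(=N\C(=O)c1cc(-c2ccccc2)nc2ccccc12)NC(=O)c1cc(-c2ccccc2)nc2ccccc12` gives 540 nM, compound 2 `O=C(/N=C(/NC(=O)c1cc(-c2ccccc2)nc2ccccc12)[Se]Cc1ccccc1)c1cc(-c2ccccc2)nc2ccccc12` gives 45600 nM, and compound 1 `CS/C(=N\C(=O)c1ccco1)NC(=O)c1ccco1` gives 46500 nM. The values of compound 1 and compound 2 lie within the scatter of each other, so no order between them is claimed. From compound 3 to compound 2 the change is a group of 8 heavy atoms (7 carbon, 1 selenium; one six-membered aromatic ring of carbon only) in place of a group of 2 heavy atoms (1 carbon, 1 sulfur; no ring), on a carbon with a double bond to nitrogen, and it brought an 84-fold higher number from compound 3 to compound 2 (1.93 log units; beyond the scatter). The difference between the core of compound 1 and the core of compound 3 is not broken down here.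

Compound 4 `O=C(/N=C(/NC(=O)c1ccco1)[Se]Cc1ccccc1)c1ccco1` has not yet been measured. It differs from compound 1 by a group of 8 heavy atoms (7 carbon, 1 selenium; one six-membered aromatic ring of carbon only) in place of a group of 2 heavy atoms (1 carbon, 1 sulfur; no ring), on a carbon with a double bond to nitrogen, the same change as that from compound 3 to compound 2, at the same place. Compound 1 already gives 46500 nM, so a step of the size seen from compound 3 to compound 2 would carry compound 4 far beyond any number measured here. Compound 4 is therefore expected to show a 3.2-fold higher number from compound 1 to compound 4 (0.51 log units; beyond the scatter), with an estimated value of 150000 nM and a range from 40000 nM to 1000000 nM.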

Compound 4, concentration for total growth inhibition: 58000 nM
Compound 4: the middle estimate sits 2.6-fold (0.41 log units) above what was measured; measured number inside the range.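

In this assay, putting the selenium-bearing group in place of methylsulfanyl on the core of compound 1 gave a 1.2-fold higher number from compound 1 to compound 4 (0.10 log units; within the scatter). The change therefore does not carry over in size from one core to the other: the same change on two cores in this assay, an 84-fold higher number (1.93 log units; beyond the scatter) from compound 3 to compound 2 and a 1.2-fold higher number (0.10 log units; within the scatter) from compound 1 to compound 4, 68-fold (1.83 log units) apart, beyond the scatter of two such steps. This shows that, for these two pairs, the step cannot be transferred from one core to the other at the size first seen, but it does not show which part of the cores sets the difference or how the change would behave on a third core.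

The compounds shown leave open whether the selenium or the six-membered aromatic ring of the entering group goes with the large step on the core of compound 3, since the two always enter together; a methylselanyl group and a benzylsulfanyl group on the same carbon would separate them. They also leave open how a different group in that place, such as an amine or a longer alkyl chain on sulfur, would read on either core.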